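Removing the substituted amino-aryl from compound 3

The source may report more compounds than this note shows. Statements on the series, on what has been measured and on what is new or still open speak of the compounds shown alone.

Measured compounds:
- compound 1 `COc1cc(-c2nn(-c3cccc(NC(=O)c4cccc(C(F)(F)F)c4)c3)cc2-c2ccncc2)ccc1Cl`: 3310 nM
- compound 2 `COc1cc(-c2nn(-c3cccc(NC(=O)c4ccc(Cl)c(C(F)(F)F)c4)c3)cc2-c2ccncc2)ccc1Cl`: 11200 nM
- compound 3 `COc1cc(-c2nn(-c3cccc(NC(=O)Nc4ccc(Cl)c(C(F)(F)F)c4)c3)cc2-c2ccncc2)ccc1Cl`: 1140 nM

In a functional assay on SN12C cells (Homo sapiens) for inhibition, read by sulforhodamine B assay, with a stated time of 48 h (on this read-out lower numbers stand for stronger inhibition of growth and higher numbers for weaker inhibition of growth), compound 3 gives the lowest number of the three, with compound 1 nearest and compound 2 furthest, and both gaps beyond the scatter. Compound 4 `COc1cc(-c2nn(-c3cccc(NC(=O)c4ccccc4)c3)cc2-c2ccncc2)ccc1Cl` is not yet measured. It differs from compound 3 in one place: phenyl in place of (4-chloro-3-(trifluoromethyl)phenyl)amino on a carbonyl carbon. Among the measured compounds shown here, two measured steps bear on this. The step from compound 2 to compound 3, a 9.8-fold lower number from compound 2 to compound 3 (0.99 log units; beyond the scatter), shows what exchanging an aryl for an amino-aryl on the carbonyl carbon did; compound 4 reverses that exchange, so the number is expected to move back up. The step of a 3.4-fold higher number from compound 1 to compound 2 (0.53 log units; beyond the scatter) shows that adding a chloro raised the number, so taking the chloro away again should pull it partly down. For the measured compounds named here, no measured pair shows what removing the trifluoromethyl does, so that part is open. Weighing the two known steps, compound 4 is expected to land clearly above compound 3 and short of compound 2. For compound 4 the expected step is a 3.9-fold higher number from compound 3 to compound 4 (0.60 log units; beyond the scatter). The estimate for compound 4 in this assay is 4500 nM, within a range from 1500 nM to 14000 nM.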

Compound 4, concentration for 50% growth inhibition: 2950 nM
Beside the measured number, compound 4's estimate is 1.5-fold (0.18 log units) above it; the measured number falls inside the stated range.
By their numbers in this assay, from the lowest: compound 3; then compounds 4 and 1 (each within the scatter of the next); then compound 2.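

In this assay, among the compounds shown here, hydrogen in place of trifluoromethyl gives a 1.1-fold lower number from compound 1 to compound 4 (0.05 log units; within the scatter), the first direct reading of that group on its own, and it shows no change that can be told from the scatter. The plain phenyl, set against the aryl carrying both chloro and trifluoromethyl, gives a 3.8-fold lower number from compound 2 to compound 4 (0.58 log units; beyond the scatter), so among the amides shown only compound 2, the one with the chloro, stands apart from the others, at the high end. The change at the carbonyl carbon also looks different with compound 4 as the reference: the step of a 2.6-fold higher number from compound 3 to compound 4 (0.41 log units; beyond the scatter) shows that compound 3 keeps its advantage over an amide without any substituents on the aryl, though the gap is smaller than a 9.8-fold lower number from compound 2 to compound 3 (0.99 log units; beyond the scatter), which therefore partly reflects how weak compound 2 is.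

Nothing shown here gives a reason for any of these steps. Still open, going by these compounds, is what a plain phenylamino on the carbonyl carbon would give, which would separate the contribution of the added nitrogen from that of the chloro and trifluoromethyl, and whether a fluoro or a nitrile in place of the chloro would raise the number as the chloro does.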